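Alkyl chain extension on the lactone core: compound 4

The source may report more compounds than this note shows. Statements on the series, on what has been measured and on what is new or still open speak of the compounds shown alone.

Compound 1 `C=C1CC(c2ccc(Br)cc2)OC1=O` — 20300 nM
Compound 2 `C=C1CC(c2ccccc2)N(C)C1=O` — 989000 nM
Compound 3 `C=C1CC(C)OC1=O` — 77400 nM

In a functional assay on HL-60 cells (Homo sapiens) for cytotoxicity, read by MTT assay, with a stated time of 48 h (on this read-out higher numbers stand for weaker inhibition and lower numbers for stronger inhibition), compound 3 gives 77400 nM, the second highest of the three numbers. Its nearest neighbour is compound 1 at 20300 nM, a gap beyond the scatter; furthest away is compound 2 at 989000 nM, also beyond the scatter.

Compound 4 `C=C1CC(CC)OC1=O` has not been measured. It differs from compound 3 by methyl in place of hydrogen on a saturated chain carbon bound to a saturated ring carbon; the same difference, cut one bond further out, reads methyl to ethyl. Among the compounds with values here, no measured pair shows this kind of change, so the expected step of a 1.3-fold lower number from compound 3 to compound 4 (0.11 log units; within the scatter) is small, if anything toward a lower number, and not beyond the scatter. For compound 4 the estimate in this assay is 60000 nM, with a range from 25000 nM to 150000 nM.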

Compound 4, half-maximal inhibitory concentration: 39500 nM
Estimate against measurement, compound 4: 1.5-fold (0.18 log units) above; the range from low to high includes it.
By their numbers in this assay, from the lowest: compounds 1, 4 and 3 (each within the scatter of the next, the first and the last beyond it); then compound 2.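

In this assay, within the data shown here, methyl in place of hydrogen on a saturated chain carbon bound to a saturated ring carbon gives a 2.0-fold lower number from compound 3 to compound 4 (0.29 log units; within the scatter) and thus the first single-place comparison. At this position, the added methyl leaves no change that can be told from the scatter. No available evidence bears on the size of this step.

From the compounds shown here alone, whether a longer chain such as propyl or butyl would stay within the scatter remains open. So does the effect of an amine or a carboxylic acid at the end of the chain.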